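This account rests on a few compounds, and the source may have more. Where it says the series, first, only, none or still open, it means among the compounds named here.

Compound 1 `Nc1cc(N)c2nc(-c3ccccc3)c(NCc3ccc(Cl)c(Cl)c3)nc2c1` and compound 2 `COc1ccc(CNc2nc3cc(N)cc(N)c3nc2-c2ccccc2)cc1OC` share one core and differ only at a saturated chain carbon bound to a nitrogen on an aromatic ring. In a functional assay on OVCAR-8 cells (Homo sapiens) for inhibition, read by sulforhodamine B assay, with a stated time of 48 h (on this read-out higher numbers stand for lower toxicity in this test and lower numbers for higher toxicity in this test), compound 1 gives < 100000 nM, which is a limit of the assay rather than a number. In this assay compound 2 likewise gives < 100000 nM, again a limit. The step that the two limits leave unreadable from compound 1 to compound 2 is therefore not readable, and compound 2 sits on (the limit of < 100000 nM in this assay, at which 2 of the 2 values shown sit). Compound 3 `Nc1cc(N)c2nc(-c3ccccc3)c(NCc3ccc(F)cc3)nc2c1` carries 4-fluorophenyl in place of 3,4-dimethoxyphenyl on a saturated chain carbon bound to a nitrogen on an aromatic ring. Among the measured compounds shown here, the only measured step that bears on this exchange is a step that the two limits leave unreadable from compound 1 to compound 2, whose size is hidden by the two limits, so neither a direction nor a size beyond the scatter can be expected in this assay, and a further limit is the most probable outcome. Compound 3 is expected to give 60000 nM, with a range from 10000 nM to 200000 nM, which means an expected step that the limit leaves unreadable from compound 2 to compound 3.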

Compound 3, concentration lethal to 50% of the cells: 21900 nM
Beside the measured number, compound 3's estimate is 2.7-fold (0.44 log units) above it; the measured number falls inside the stated range.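

Among the compounds shown here, compound 3 has a number in this assay, but compound 1 and compound 2 stand there only as limits, so no new step to compound 3 can be read from either. The compounds shown leave open how far, and in which direction, compound 1 and compound 2 lie from compound 3: the limit of < 100000 nM in this assay, at which 2 of the 3 values shown sit.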